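This account rests on a few compounds, and the source may have more. Where it says the series, first, only, none or still open, it means among the compounds named here.

Measured so far in an ADME assay on the whole organism (Rattus norvegicus, strain Wister-Han) for pharmacokinetics, read by LC-MS, at a dose of 3 mg/kg by the oral route; on this read-out higher numbers stand for higher oral bioavailability and lower numbers for lower oral bioavailability:
- compound 1 `Cc1ccncc1C(=O)N1CC(Oc2cncc(N3C(=O)c4ccc(Cl)cc4C3(C)C)c2)C1`: 40%
- compound 2 `CCS(=O)(=O)N1CCC(c2cncc(N3C(=O)c4ccc(Cl)cc4C3(C)C)c2)CC1`: 87%
- compound 3 `CC1(C)c2cc(Cl)ccc2C(=O)N1c1cncc(N2CCN(S(C)(=O)=O)CC2)c1`: 54%

Compound 1 is the lowest of these three. Compound 3 is its nearest neighbour and compound 2 the furthest, and both lie above it beyond the scatter.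

The next compound to be measured is compound 4 `CCS(=O)(=O)N1CC(Oc2cncc(N3C(=O)c4ccc(Cl)cc4C3(C)C)c2)C1`, which departs from compound 1 in one place: ethylsulfonyl in place of (4-methylpyridin-3-yl)carbonyl on an amine nitrogen in a ring. Ethylsulfonyl replaces (4-methylpyridin-3-yl)carbonyl on an amine nitrogen in a ring, and the rest of the structure stays the same.

Among the compounds with values here, no two measured compounds differ in one place only, so the series offers no direct measure of this change. The indirect evidence is limited. Compound 2 also carries ethylsulfonyl and gives 87%, but it differs from compound 4 in more than one respect. Compound 3 has a sulfonyl group too and gives 54%, again on a different structure. Both point upward from compound 1, so a rise in this assay beyond the scatter is expected, though probably not the full gap up to compound 2. The expected step is a number 25 percentage points higher from compound 1 to compound 4 (beyond the scatter).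

For compound 4 the estimated value is 65%, with an expected range from 45% to 85%.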

Compound 4, oral bioavailability: 45%
The estimate for compound 4 lay 20 percentage points above the measured number; the measured number falls inside the stated range.
By their numbers in this assay, from the lowest: compounds 1, 4 and 3 (each within the scatter of the next, the first and the last beyond it); then compound 2.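

In this assay, the exchange at this position gives a number 5 percentage points higher from compound 1 to compound 4 (within the scatter), so on the amine nitrogen of the four-membered ring, ethylsulfonyl and (4-methylpyridin-3-yl)carbonyl cannot be told apart on this read-out. Within the data shown here, this is the first direct reading of a single change, and it shows that the six-membered aromatic ring with its hetero atom can leave this position, with the group going from 9 heavy atoms to 5, without a step beyond the scatter. No measurement bears on why the read-out responds in this way to the exchange.

The compounds shown leave open whether any group on this nitrogen moves the number beyond the scatter, since an acetyl group, a simple alkyl chain, a primary amine or a carboxylic acid at this place would test a wider range than these two groups. It also remains open what the four-membered ring itself contributes, as no pair shown changes that ring alone while ethylsulfonyl stays in place.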